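This account rests on a few compounds, and the source may have more. Where it says the series, first, only, none or still open, it means among the compounds named here.

Two compounds that share one core have been run in a functional assay on 3T3-L1 cells (Mus musculus) for inhibition, with a stated time of 20 min, tested at 20 uM; a higher number here means more inhibition at the concentration tested (going by the name of the read-out), a lower number less inhibition. Compound 1 `Cc1ccc(S(=O)(=O)N(Cc2cccc(F)c2F)Cc2cn(S(=O)(=O)c3ccc(F)cc3)c3ccccc23)cc1` gives -35% in this assay. Compound 2 `Fc1cccc(CNCc2c[nH]c3ccccc23)c1F` gives -1.7% in this assay; this is the higher of the two numbers, and its gap to compound 1 lies beyond the usual scatter of such repeated measurements. A third compound, compound 3 `O=S(=O)(c1ccc(F)cc1)n1cc(CNCc2cccc(F)c2F)c2ccccc21`, has not yet been measured. Relative to compound 2 it carries one change: (4-fluorophenyl)sulfonyl in place of hydrogen on an aromatic nitrogen. Going by the values given here, no pair of measured compounds shows this change on its own, so no measured step can guide the guess directly. In this assay the expected step is a number 13.3 percentage points lower from compound 2 to compound 3 (beyond the scatter), a modest move downward rather than none at all. Compound 3 is accordingly estimated at -15%, with a likely range from -45% to 15%.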

Compound 3, a percentage reported as inhibition, at one concentration (the size of the read-out at that concentration, not a potency): 21%
For compound 3 the middle estimate is 36 percentage points below the measured one; measured number above the stated range.
By their numbers in this assay, from the lowest: compound 1; then compound 2; then compound 3.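

In this assay the swap of hydrogen for (4-fluorophenyl)sulfonyl on the aromatic nitrogen gives a number 22.7 percentage points higher from compound 2 to compound 3 (beyond the scatter) and so shows that this position responds to the change. The amine nitrogen responds as well: with the group on the aromatic nitrogen unchanged, hydrogen in place of (4-methylphenyl)sulfonyl gives a number 56 percentage points higher from compound 1 to compound 3 (beyond the scatter) and reveals a second place where the read-out shifts. Going by these compounds alone, compound 3, which carries the sulfonyl group on the aromatic nitrogen and hydrogen on the amine nitrogen, stands highest of the three in this assay at 21% as the only positive number.

As far as these compounds go, whether a methyl or an acetyl on the aromatic nitrogen would move the number in the same direction remains open. Nothing available explains why either change shifts the number.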